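Urea-linked aminoindazoles: butoxy for benzyl on the aryl ring

This account rests on a few compounds, and the source may have more. Where it says the series, first, only, none or still open, it means among the compounds named here.

Three compounds of this urea series have a number or a limit in a functional assay on TK-10 cells (Homo sapiens) for inhibition, read by sulforhodamine B assay, with a stated time of 48 h; on this read-out lower numbers stand for stronger inhibition of growth and higher numbers for weaker inhibition of growth. Compound 1 `O=C(Nc1ccccc1OC(F)(F)F)Nc1n[nH]c2ccccc12` gives 37900 nM in this assay. Compound 2 `Nc1nn(C(=O)Nc2ccc(Cc3ccccc3)cc2)c2ccccc12` gives 27200 nM in this assay, the lower of the two numbers shown, but the gap to compound 1 lies within the scatter of repeated runs, so the two are not told apart. Among the compounds with values here, compound 3 `COc1ccc(NC(=O)Nc2n[nH]c3ccccc23)cc1` reaches only a limit in this assay, > 100000 nM, a limit of the method rather than a number; it is the single value of that kind in the set (the limit of > 100000 nM in this assay, at which 1 of the 3 values shown sits).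

Compound 4 `CCCCOc1ccc(NC(=O)n2nc(N)c3ccccc32)cc1` has not yet been run in this assay. It differs from compound 2 in one place: butoxy in place of benzyl on an aromatic carbon. Within the data shown here, no measured pair in the set isolates this exchange, so the size of the step cannot be read from the data. Against the one measured alkoxy analogue, compound 3, sitting at a limit, the exchange is expected to leave compound 4 no stronger than compound 2 and more likely somewhat weaker, with a fair chance that only a limit is returned. Compound 4 is estimated at 50000 nM, with a range of 20000 nM to 150000 nM. This estimate corresponds to an expected step of a 1.8-fold higher number from compound 2 to compound 4 (0.26 log units; within the scatter).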

Compound 4, concentration for 50% growth inhibition: 24200 nM
Beside the measured number, compound 4's estimate is 2.1-fold (0.32 log units) above it; the measured number falls inside the stated range.
By their numbers in this assay, from the lowest: compounds 4, 2 and 1 (each within the scatter of the next). At a limit, above all of these: compound 3.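

In this assay the exchange of benzyl for butoxy, on an aromatic carbon para to a large group, gives a 1.1-fold lower number from compound 2 to compound 4 (0.05 log units; within the scatter) and so does not separate the two compounds. This place on the aryl ring therefore accepts the loss of the six-membered aromatic ring and the entry of a hydrogen-bond acceptor, with 5 heavy atoms in place of 7, and no readable shift in growth inhibition follows; on this pair, the ring of benzyl is not needed to hold the number at this level. Nothing measured in the set gives a cause for this flat step.

Still open, on these data alone, is whether a longer chain such as octyloxy, a shorter one such as ethoxy, or an amine or a carboxylic acid at the same place would also leave the number unchanged or would separate from compound 2 by more than the scatter. A single pair also leaves open whether the exchange would read the same on the core of compound 1, where the urea is attached differently.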